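The compounds below may be only part of what the source reports. "The series", "measured", "known", "first", "only" and "open" are said of these compounds alone.

Measured compounds in an assay for inhibition of cytochrome P450 1A1 (Homo sapiens), read by fluorescence, using microsomes, with a stated time of 10 min; on this read-out higher numbers stand for weaker inhibition and lower numbers for stronger inhibition:
Compound 1 `O=C(/C=C/c1ccccc1F)c1ccc[nH]1`: > 20000 nM, a limit of the assay.
Compound 2 `O=C(/C=C/c1ccc(Br)cc1)c1ccc[nH]1`: > 20000 nM, a limit of the assay.
Compound 3 `COc1cccc(/C=C/C(=O)c2ccc[nH]2)c1`: 6200 nM.

Compound 2 stands at the limit of > 20000 nM in this assay, at which 2 of the 3 values shown sit, so for compound 2 there is no number, only a limit. Among the measured compounds shown here, compound 3 is the one member of the set with a numerical value in this assay. Compound 4 `CN(C)c1ccc(/C=C/C(=O)c2ccc[nH]2)cc1` is not yet measured in this assay. It differs from compound 2 by dimethylamino in place of bromo on an aromatic carbon. For the measured compounds named here, no step between measured compounds is available to anchor the size of this change. The expected step from compound 2 to compound 4 is an at least 2.2-fold lower number from compound 2 to compound 4 (0.34 log units; beyond the scatter), toward stronger inhibition, though a reading that again stops at the limit remains quite possible. Compound 4 is estimated at 9000 nM, with a range from 2500 nM to 30000 nM.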

Compound 4, half-maximal inhibitory concentration: > 20000 nM
Compound 4 was reported as a limit; the forecaster's own chance of this, stated with the estimate: 40%; at least 2.2-fold (0.34 log units) between middle value and limit.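

Among the compounds shown here, compound 2 and compound 4 both stop at an assay limit, so no step between them can be read. Going by these compounds, whether dimethylamino in place of bromo on an aromatic carbon shifts inhibition at all remains open.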